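Swapping a Chloro Group for a Nitrobenzoate Ester

The compounds below may be only part of what the source reports. "The series", "measured", "known", "first", "only" and "open" are said of these compounds alone.

Measured so far:
compound 1 `CC(C)=CCC[C@]1(C)/C=C/[C@@H](OC(=O)C=C(C)C)[C@](C)(O)/C=C/C(=O)/C(CCl)=C\C1`: 150 nM
compound 2 `CC(C)=CCC[C@]1(C)/C=C/[C@@H](OC(=O)C=C(C)C)[C@](C)(O)CCC(=O)/C(CO)=C\C1`: > 40000 nM

In a functional assay on A549 cells (Homo sapiens) for antiproliferative activity, read by MTT assay, with a stated time of 48 h (on this read-out higher numbers stand for weaker inhibition and lower numbers for stronger inhibition), compound 1 gives 150 nM. For compound 2 this assay reports only a limit, > 40000 nM, not a number. Compound 1 therefore holds the only true number shown, while the other entry is a limit, (the limit of > 40000 nM in this assay, at which 1 of the 2 values shown sits). Compound 3 `CC(C)=CCC[C@]1(C)/C=C/[C@@H](OC(=O)C=C(C)C)[C@](C)(O)/C=C/C(=O)/C(COC(=O)c2ccc([N+](=O)[O-])cc2)=C\C1` has not yet been measured. It differs from compound 1 by ((4-nitrophenyl)carbonyl)oxy in place of chloro on a saturated chain carbon bound to a double-bonded ring carbon. Among the compounds with values here, no measured pair differs in one place only, so no measured step guides this change, and the expectation rests on compound 1 alone. The step of a 2.7-fold higher number from compound 1 to compound 3 (0.43 log units; beyond the scatter) is expected to be small, toward weaker inhibition if anything, and may not exceed the usual scatter. Compound 3 is estimated at 400 nM, with a range from 100 nM to 2000 nM.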

Compound 3, half-maximal inhibitory concentration: 1310 nM
Estimate against measurement, compound 3: 3.3-fold (0.52 log units) below; measured number inside the range.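

In this assay, within the data shown here, putting ((4-nitrophenyl)carbonyl)oxy in place of chloro gives an 8.7-fold higher number from compound 1 to compound 3 (0.94 log units; beyond the scatter), the first change in a single place that can be read. It shows that the saturated chain carbon bound to a double-bonded ring carbon is sensitive to the group it carries, yet this exchange does not abolish activity: compound 3 still gives a true number, 1310 nM, and inhibition is weakened rather than lost. Nothing shown explains why the step has this size.

Among these compounds, with only two groups compared at this place, it stays open whether the weaker inhibition comes from losing chloro or from the features of the entering group. A simple acetate ester, an unsubstituted benzoate or an amine at the same carbon could separate these possibilities.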